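From Methoxy to Methyl on a Benzyl Amide

A few compounds are considered here, and "the series" means these few. Any claim that something is new, unique, unknown or untested is made for them only; others in the source may bear on it.

In a functional assay on HeLa cells (Homo sapiens) for inhibition, read by MTT assay, with a stated time of 48 h (on this read-out higher numbers stand for weaker inhibition and lower numbers for stronger inhibition), compound 1 (`COc1ccc2c(=O)c(/C=C/C(=O)Nc3cc(C)ccc3C)coc2c1`) gives 58400 nM. Compound 2 (`COc1ccc(CNC(=O)/C=C/c2coc3cc(OC)ccc3c2=O)cc1`) gives > 100000 nM, which is a limit of the assay and not a number. Its standing is therefore only this: the limit of > 100000 nM in this assay, at which 1 of the 2 values shown sits.

Compound 3 (`COc1ccc2c(=O)c(/C=C/C(=O)NCc3ccc(C)cc3)coc2c1`) has methyl in place of methoxy on an aromatic carbon, para to a large group: methyl in place of methoxy on an aromatic carbon. Among the measured compounds shown here, the one measured step, an at least 1.7-fold higher number from compound 1 to compound 2 (0.23 log units; that floor lies within the scatter), puts 4-methoxybenzyl in place of 2,5-dimethylphenyl on an amide-type nitrogen, so it is a different change and only an indirect guide. For the measured compounds named here, with that step as the sole evidence, no change beyond the scatter is expected in this assay, in either direction. The expected step is an at least 1.1-fold lower number from compound 2 to compound 3 (0.04 log units; that floor lies within the scatter). Compound 3 is estimated at 90000 nM, with an expected range from 40000 nM to 200000 nM.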

Compound 3, half-maximal inhibitory concentration: > 100000 nM
Compound 3 gave a limit, no number; the forecaster's own chance of this, stated with the estimate: 55%; at least 1.1-fold (0.04 log units) between middle value and limit.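

In this assay, compound 3 gives only a limit and not a number, just as compound 2 does, so the step between them cannot be read, and putting methyl in place of methoxy does not bring the benzyl amide back to a readable value. Measured against the 2,5-dimethylphenyl amide, the change to 4-methylbenzyl gives an at least 1.7-fold higher number from compound 1 to compound 3 (0.23 log units; that floor lies within the scatter), which alone does not establish a real difference. What is new is that two different groups at this position on the benzyl ring end at the same place: the limit of > 100000 nM in this assay, at which 2 of the 3 values shown sit.

As far as these compounds go, how far compound 2 and compound 3 each lie past that limit stays unknown. Also open, from the compounds shown here alone, is whether an amine or a carboxylic acid at this position, or a benzyl ring carrying no group there, would give a readable number.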